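This account rests on a few compounds, and the source may have more. Where it says the series, first, only, none or still open, it means among the compounds named here.

Working notes on the series. Compound 1, `COc1cc(N(Cc2ccc(Cl)cc2)C(=O)CSc2nc3ccccc3s2)cc(OC)c1OC`, and compound 2, `COc1cc(N(Cc2ccc(F)cc2)C(=O)CSc2nc3ccccc3s2)cc(OC)c1OC`, share one core and differ only in the halogen on the benzyl ring. In a functional assay on PC-3 cells (Homo sapiens) for antiproliferative activity, read by MTT assay, with a stated time of 48 h (a higher number here means a weaker inhibitor, a lower number a stronger inhibitor), compound 2 gives 50800 nM. For compound 1 this assay returns only a limit, > 80000 nM. Going by the values given here, the single measured step, an at least 1.5-fold lower number from compound 1 to compound 2 (0.19 log units; that floor lies within the scatter), rests on the limit of > 80000 nM in this assay, at which 1 of the 2 values shown sits, and so marks a floor rather than a size. Among the compounds with values here, compound 2 therefore holds the only firm number in this assay; nothing further is claimed on its order against compound 1.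

Compound 3, `COc1cc(N(Cc2ccc(Br)cc2)C(=O)CSc2nc3ccccc3s2)cc(OC)c1OC`, is the next member: bromo in place of fluoro on an aromatic carbon. The measured step bears on it only as a halogen exchange at the same aromatic carbon, run in the opposite sense and carried on to bromo. A number on the weaker side of compound 2 is expected, and a second limit is plausible. Compound 3 is expected to give about 90000 nM in this assay, within a range from 40000 nM to 200000 nM. The estimated step of a 1.8-fold higher number from compound 2 to compound 3 (0.25 log units; within the scatter) is expected to pass beyond the scatter only at the upper end of that range.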

Compound 3, half-maximal inhibitory concentration: > 80000 nM
Compound 3: only a limit was reported; the forecaster's own chance of this, stated with the estimate: 55%; the middle value does not contradict the limit.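

Going by these compounds alone, with bromo on this aromatic carbon, para to a large group, compound 3 joins compound 1 at the limit of this assay, and compound 2, with fluoro, keeps the only firm number among the three halogens. The exchange of fluoro for bromo reads as an at least 1.5-fold higher number from compound 2 to compound 3 (0.19 log units; that floor lies within the scatter), which marks a floor and not a size, so this second halogen step also gives no reading beyond the scatter. The step between compound 1 and compound 3 cannot be read, and what this position shows rests on a single bound: the limit of > 80000 nM in this assay, at which 2 of the 3 values shown sit.

From the compounds shown here alone, whether any two of these halogens truly differ in this assay stays open. Also open, going by these compounds, is how an amine or a carboxylic acid on the same carbon would read, and whether either would give a firm number rather than a limit.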